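Lengthening the chain on the amide-type nitrogen

The compounds below may be only part of what the source reports. "The series", "measured", "known", "first", "only" and "open" are said of these compounds alone.

Measured so far:
Compound 1, `CNC(=S)N1N=C(c2ccc(C)cc2)CC1c1ccc[nH]1`, gives 349000 nM in an assay for inhibition of Amine oxidase [flavin-containing] B (Rattus norvegicus), with a stated time of 60 min; a higher number here means a weaker inhibitor, a lower number a stronger inhibitor.
Compound 2, `CCNC(=S)N1N=C(c2ccc(C)cc2)CC1c1ccc[nH]1`, gives 369000 nM in this assay.

Both compounds share one core and differ only in the chain on the amide-type nitrogen. The step of a 1.1-fold higher number from compound 1 to compound 2 (0.02 log units; within the scatter) changes little, so compound 2 stands beside compound 1 rather than apart from it; both are weak inhibitors in this assay.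

Compound 3, `CCCNC(=S)N1N=C(c2ccc(C)cc2)CC1c1ccc[nH]1`, carries the change (methyl in place of hydrogen on a saturated chain carbon, two bonds along the chain from an amide-type nitrogen). Among the measured compounds shown here, the only measured step that bears on it is a 1.1-fold higher number from compound 1 to compound 2 (0.02 log units; within the scatter), where the same kind of group was added on the chain carbon bound to the amide-type nitrogen, and that step stayed within the scatter. The same kind of change made one bond further out is therefore expected to leave the number about where it is, a 1.0-fold higher number from compound 2 to compound 3 (0.01 log units; within the scatter). Compound 3 is estimated at 380000 nM in this assay, with a range from 190000 nM to 760000 nM.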

Compound 3, half-maximal inhibitory concentration: 389000 nM
The estimate for compound 3 lay 1.0-fold (0.01 log units) below the measured number; the measured number falls inside the stated range.
By their numbers in this assay, from the lowest: compounds 1, 2 and 3 (each within the scatter of the next).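

In this assay, methyl in place of hydrogen two bonds along the chain from the amide-type nitrogen gives a 1.1-fold higher number from compound 2 to compound 3 (0.02 log units; within the scatter) and so, like the earlier step one bond closer in, does not separate the two compounds. The larger change, ethyl in place of hydrogen on the saturated chain carbon bound to that nitrogen, gives a 1.1-fold higher number from compound 1 to compound 3 (0.05 log units; within the scatter) and so even the end-to-end comparison, from the methyl of compound 1 to the propyl of compound 3, stays within what repeated measurements would show. No supporting measurement bears on this result.

On these data alone, whether a longer chain such as butyl would move the number beyond the scatter remains open. So does the effect of a chain ending in an amine or a carboxylic acid.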